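The source may report more compounds than this note shows. Statements on the series, on what has been measured and on what is new or still open speak of the compounds shown alone.

- Compound 1 `c1cnc2c(c1)CCC[C@@H]2N(CC1CC1)C[C@H]1Cc2c(cccc2N2CCNCC2)CN1`: 88.3%
- Compound 2 `CN(C[C@H]1Cc2c(cccc2N2CCNC(C)(C)C2)CN1)[C@H]1CCCc2cccnc21`: 44%
- Compound 3 `CN(C[C@H]1Cc2c(cccc2N2CCN(c3cccc(C(F)(F)F)c3)CC2)CN1)[C@H]1CCCc2cccnc21`: 72.3%

In an ADME assay on microsomes from liver (Mus musculus) for metabolic stability, read by LC-MS, with a stated time of 10 min (on this read-out lower numbers stand for a less stable compound and higher numbers for a more stable compound), compound 1 stands highest of the three. Compound 3 lies nearest to it and compound 2 furthest away, and both gaps are beyond the usual scatter.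

Compound 4 `CCCN(C[C@H]1Cc2c(cccc2N2CCNCC2)CN1)[C@H]1CCCc2cccnc21` has not yet been measured. It differs from compound 1 in one place: ethyl in place of cyclopropyl on a saturated chain carbon bound to an amine nitrogen. This puts ethyl in place of cyclopropyl on a saturated chain carbon bound to an amine nitrogen.

Among the measured compounds shown here, no measured pair shows a change of this kind, so the expectation is tentative: a modest fall in this assay, near the edge of the scatter. The expected change is a number 12.3 percentage points lower from compound 1 to compound 4 (beyond the scatter). The estimated value for compound 4 is 76%, with an expected range of 55% to 92%.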

Compound 4, percent of the compound remaining: 87.4%
Compound 4: the middle estimate sits 11.4 percentage points below what was measured; the range from low to high includes it.
By their numbers in this assay, from the lowest: compound 2; then compound 3; then compounds 4 and 1 (each within the scatter of the next).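

In this assay, ethyl in place of cyclopropyl gives a number 0.9 percentage points lower from compound 1 to compound 4 (within the scatter). At this place, on a saturated chain carbon bound to an amine nitrogen, the three-membered ring can therefore go without a change beyond the scatter, and an open chain serves as well on this read-out. Nothing shown explains why the two compounds read alike. Still open, on these data alone, is whether a longer chain such as butyl, or a chain ending in a carboxylic acid, would also leave this read-out in place.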